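Sulfur substituent lengthened on a guanidine-carbonyl benzene core

The source may report more compounds than this note shows. Statements on the series, on what has been measured and on what is new or still open speak of the compounds shown alone.

Of the compounds shown here, two sharing one core have been measured in a functional assay for inhibition of sodium/hydrogen exchanger (Oryctolagus cuniculus); on this read-out higher numbers stand for weaker inhibition and lower numbers for stronger inhibition. Compound 1 `Cc1cc(Br)c(S(C)(=O)=O)cc1C(=O)N=C(N)N` carries a bromo group on its aromatic ring, and in this assay compound 1 gives 12 nM. Compound 2 `CSc1cc(C)c(C(=O)N=C(N)N)cc1S(C)(=O)=O` has a methylsulfanyl group in that place, and in this assay compound 2 gives 6 nM. The step of a 2.0-fold lower number from compound 1 to compound 2 (0.30 log units; within the scatter) shows that these two numbers cannot be told apart by this read-out, so compound 2 stands alongside compound 1 rather than ahead of it.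

Compound 3 `Cc1cc(SC(C)C)c(S(C)(=O)=O)cc1C(=O)N=C(N)N` is the next member, not yet measured. Its difference from compound 2 is isopropyl in place of methyl on a sulfur. Among the compounds with values here, no measured step touches this change: the only step available swaps bromo for methylsulfanyl, and nothing in the data shows what growing the chain on the sulfur does. The expectation therefore leans on the observation that the two measured numbers sit close together, leaving the direction of any shift open. Compound 3 is expected to give 8 nM, with a plausible range from 2 nM to 30 nM. This estimate means a step of a 1.3-fold higher number from compound 2 to compound 3 (0.12 log units; within the scatter), expected to stay within the scatter.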

Compound 3, half-maximal inhibitory concentration: 12 nM
Compound 3: the middle estimate sits 1.5-fold (0.18 log units) below what was measured; the measured number falls inside the stated range.
By their numbers in this assay, from the lowest: compounds 2, 1 and 3 (each within the scatter of the next).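

Growing the group on the sulfur from methyl to isopropyl gives a 2.0-fold higher number from compound 2 to compound 3 (0.30 log units; within the scatter) in this assay, so the first change made to the sulfur chain itself produces no difference that this read-out can resolve. Replacing bromo with isopropylsulfanyl on the aromatic carbon gives no change at the digits printed from compound 1 to compound 3 (within the scatter), so across the three compounds, bromo, methylsulfanyl and isopropylsulfanyl cannot be told apart at this place, even though the group on the sulfur goes from methyl to the larger isopropyl. Nothing available explains why these numbers stay so close together.

These three compounds show only that this small range of groups gives indistinguishable numbers, and they cannot show how far that holds once the group on the sulfur grows to a longer chain such as n-hexyl or to a ring such as phenyl. Going by these compounds, whether an amine or a carboxylic acid at the end of that chain, or in place of the sulfur group altogether, would keep the number at this level also remains open.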